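Benzoyl for propyl on the ring nitrogen acyl group

The source may report more compounds than this note shows. Statements on the series, on what has been measured and on what is new or still open speak of the compounds shown alone.

Measured compounds:
Compound 1 `O=C(Nc1ccccc1O)C1CCc2ccccc2N1C(=O)c1ccc(Cl)cc1` gives 19600 nM in a functional assay on MDA-MB-231 cells (Homo sapiens) for cytotoxicity, read by sulforhodamine B assay, with a stated time of 72 h; on this read-out higher numbers stand for weaker inhibition of growth and lower numbers for stronger inhibition of growth.
Compound 2 `CCCC(=O)N1c2ccccc2CCC1C(=O)Nc1cc(C(F)(F)F)cc(C(F)(F)F)c1` gives 15200 nM in this assay.
Compound 3 `O=C(Nc1ccccc1C(F)(F)F)C1CCc2ccccc2N1C(=O)c1ccc(Cl)cc1` gives 533 nM in this assay.

Compound 2 stands second highest of the three numbers. Compound 1 lies nearest to it, within the scatter, while compound 3 lies furthest, with a number beyond the scatter below that of compound 2. For the measured compounds named here, the one step between compounds that differ in a single place is a 37-fold lower number from compound 1 to compound 3 (1.57 log units; beyond the scatter), and it concerns the substituent on the aromatic carbon of the amide partner, not the acyl group on the ring nitrogen.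

Compound 4 `O=C(Nc1cc(C(F)(F)F)cc(C(F)(F)F)c1)C1CCc2ccccc2N1C(=O)c1ccccc1` is not yet measured. It differs from compound 2 by phenyl in place of propyl on a carbonyl carbon. No measured step changes this acyl group, so the size of the step cannot be read from a shown pair. Compounds 1 and 3 both carry an aroyl group on that nitrogen, and compound 3 shows the lowest number of the set, which is the only hint that such a group is compatible with a low number. The expectation is therefore a moderate step downward in this assay, stated with a wide range. The estimate for compound 4 is 4000 nM, between 800 nM and 20000 nM, meaning an expected step of a 3.8-fold lower number from compound 2 to compound 4 (0.58 log units; beyond the scatter).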

Compound 4, concentration for 50% growth inhibition: 2430 nM
Beside the measured number, compound 4's estimate is 1.6-fold (0.22 log units) above it, within the range that was stated.
By their numbers in this assay, from the lowest: compound 3; then compound 4; then compounds 2 and 1 (each within the scatter of the next).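

In this assay, the change from propylcarbonyl to benzoyl gives a 6.3-fold lower number from compound 2 to compound 4 (0.80 log units; beyond the scatter), and this is the only step shown at this acyl group. The earlier compounds shown here offered only a hint from their shared aroyl groups, whereas this single-place pair shows directly that the group on a carbonyl carbon whose other neighbour is an amide-type nitrogen in a ring influences the growth-inhibition number, with the entering phenyl, a six-membered aromatic ring of carbon only, going with the lower number and a step beyond the scatter. No available evidence bears on why the number falls with this change.

From the compounds shown here alone, whether a longer chain, a cyclohexyl group or a phenyl carrying a carboxylic acid would give a lower or higher number on this carbonyl carbon remains open. This change also appears with only one amide partner, so the compounds shown cannot tell whether a step of this size would hold with the amide partners of compound 1 or compound 3.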